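A few compounds are considered here, and "the series" means these few. Any claim that something is new, unique, unknown or untested is made for them only; others in the source may bear on it.

Compound 1 `COc1ccc(SCc2ccc(/C=C/C(=O)Nc3ccccc3N)cc2)cc1OC` is one of three compounds tested in a functional assay on A549 cells (Homo sapiens) for inhibition, read by CCK-8 assay, with a stated time of 72 h, tested at 2 uM; a higher number here means more inhibition of growth at the concentration tested, a lower number less inhibition of growth. In that assay compound 1 gives 65.5%, the second highest of the three numbers. Compound 2 `Nc1ccccc1NC(=O)c1ccc(CSc2nccc(C(F)(F)F)n2)cc1` gives 75.4%, which lies within the usual scatter of the value of compound 1, so the two cannot be told apart. Compound 3 `Nc1ccccc1NC(=O)c1ccc(CSc2ccc(Br)cc2)cc1` gives 33.2%, a number clearly lower than that of compound 1, beyond the scatter. Compound 3 differs from compound 1 in more than one place, so nothing can be said about which part of the structure accounts for the gap between them.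

The next compound, compound 4 `Nc1ccccc1NC(=O)/C=C/c1ccc(CSc2ccc(Cl)cc2)cc1`, has not yet been measured. It differs from compound 1 in a single place: 4-chlorophenyl in place of 3,4-dimethoxyphenyl on a sulfur. Going by the values given here, no pair of measured compounds shows the effect of exactly this exchange. Among the compounds with values here, the only measured compound that carries a halogen-bearing phenyl on the sulfur is compound 3, and its value of 33.2% is the lowest of the set, though it also differs from compound 1 elsewhere. On that slim basis, the step from compound 1 to compound 4 is expected to be a moderate decrease, a number 15.5 percentage points lower from compound 1 to compound 4 (beyond the scatter), with a wide range because the evidence is indirect. Compound 4 is therefore estimated to reach about 50%, most likely between 30% and 70%.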

Compound 4, percent growth inhibition at one concentration: 55.3%
Compound 4: the middle estimate sits 5.3 percentage points below what was measured; the range from low to high includes it.
By their numbers in this assay, from the lowest: compound 3; then compound 4; then compounds 1 and 2 (each within the scatter of the next).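

Going by these compounds alone, this is the first direct look at the group on a sulfur with the rest of the molecule held the same. In this assay, putting 4-chlorophenyl in place of 3,4-dimethoxyphenyl gives a number 10.2 percentage points lower from compound 1 to compound 4 (beyond the scatter) and counts as a modest step. The 3,4-dimethoxyphenyl group is therefore not essential for growth inhibition at this position, since compound 4, whose new group has no hydrogen-bond acceptors, still gives 55.3% in this assay and stays well above zero, but nothing available explains why the number falls.

This one exchange changes two things together, removing the methoxy groups and adding a chlorine, so it cannot show which of them accounts for the step. Still open, on these data alone, is how the number would respond to a plain phenyl, a 4-methoxyphenyl or a 4-fluorophenyl on the sulfur, or to a group of another kind there, such as a carboxylic acid or an amine, and each of these would help separate the contribution of the methoxy groups from that of the chlorine.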